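The source may report more compounds than this note shows. Statements on the series, on what has been measured and on what is new or still open speak of the compounds shown alone.

In an ADME assay on BJ cells (Homo sapiens) for cytotoxicity, read by luminescence, with a stated time of 72 h (on this read-out higher numbers stand for an effect only at larger amounts of compound and lower numbers for an effect already at smaller amounts), three related compounds have been measured. Compound 1 `CCOC(=O)c1c(-c2cccc(Oc3ccccc3)c2)[nH]c2cc(OC)c(Cl)cc2c1=O` reaches only a limit of the assay, > 21500 nM. Compound 2 `CCOC(=O)c1c(-c2cccc(Oc3ccccc3)c2)[nH]c2cc(OC)c(F)cc2c1=O` likewise gives only a limit, > 21500 nM. Compound 3 `CCOC(=O)c1c(-c2cccc(F)c2)[nH]c2cc(OC)c(F)cc2c1=O` also gives only a limit, > 21500 nM. Compound 2 and compound 3 differ in their cores by fluoro in place of phenoxy on an aromatic carbon. From compound 2 to compound 1 the change is chloro in place of fluoro on an aromatic carbon, and the step is a step that the two limits leave unreadable from compound 2 to compound 1. Compound 4 `CCOC(=O)c1c(-c2cccc(Cl)c2)[nH]c2cc(OC)c(F)cc2c1=O` is not yet measured and differs from compound 3 by chloro in place of fluoro on an aromatic carbon. The two changes are the same kind of change, not the same: one place is part of a fused or bridged system of two rings and ortho to a methoxy group, the other is meta to a large group. Resting on (the limit of > 21500 nM in this assay, at which 3 of the 3 values shown sit), the step is expected to be a step that the limit leaves unreadable from compound 3 to compound 4. Compound 4 is estimated at 30000 nM, likely between 15000 nM and 90000 nM.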

Compound 4, half-maximal effective concentration: > 21500 nM
Compound 4: no number, only a limit; the forecaster's own chance of this, stated with the estimate: 85%; the middle value does not contradict the limit.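

Compound 4, like compound 2 and compound 3, gives only a limit, and neither step to compound 4 can be read. The compounds shown leave open whether any of them differs from another in this assay: the limit of > 21500 nM in this assay, at which 4 of the 4 values shown sit.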